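The compounds below may be only part of what the source reports. "The series", "measured", "known", "first", "only" and "open" are said of these compounds alone.

Measured compounds:

compound 1, `COc1ccc(F)cc1CNCCCNc1ccnc2cc(Oc3cccc(N(C)C)c3)ccc12`, 14500 nM
compound 2, `COc1ccc(F)cc1CNCCCNc1ccnc2cc(CCC(C)C)ccc12`, 4200 nM
compound 3, `COc1ccc(F)cc1CNCCCNc1ccnc2cc(CC(C)C)ccc12`, 4200 nM

In a physicochemical assay for solubility, with a stated time of 18 h, at pH 7.4 (a higher number here means a more soluble compound, a lower number a less soluble compound), compound 3 stands level with compound 2 at the digits shown, and the two together hold the lowest numbers of the three; compound 1 sits higher. The step of no change at the digits printed from compound 2 to compound 3 (within the scatter) lies within the scatter, while a 3.5-fold lower number from compound 1 to compound 3 (0.54 log units; beyond the scatter) and a 3.5-fold lower number from compound 1 to compound 2 (0.54 log units; beyond the scatter) both lie beyond it.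

Compound 4, `COc1ccc(F)cc1CNCCCNc1ccnc2cc(Oc3ccccc3OC)ccc12`, is not yet measured. The change from compound 3 is 2-methoxyphenoxy in place of isobutyl on an aromatic carbon.

The step that bears most directly on this change is the reverse of a 3.5-fold lower number from compound 1 to compound 3 (0.54 log units; beyond the scatter): there an aryloxy group at the same position was exchanged for isobutyl and the number fell. Compound 4 brings an aryloxy group back at that position, although with a methoxy rather than a dimethylamino substituent, so a return toward the number of compound 1 is expected, but with less confidence on its full size. The step of a 2.0-fold higher number from compound 3 to compound 4 (0.31 log units; beyond the scatter) is therefore expected to be upward and modest. For compound 4 the expected value in this assay is 8500 nM, with a range from 3000 nM to 22000 nM.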

Compound 4, solubility: 14500 nM
Estimate against measurement, compound 4: 1.7-fold (0.23 log units) below, and the stated range covers the measured number.
By their numbers in this assay, from the lowest: compounds 2 and 3 (each within the scatter of the next); then compounds 1 and 4 (each within the scatter of the next).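

In this assay, 2-methoxyphenoxy in place of isobutyl on this aromatic carbon gives a 3.5-fold higher number from compound 3 to compound 4 (0.54 log units; beyond the scatter) and in place of isopentyl gives a 3.5-fold higher number from compound 2 to compound 4 (0.54 log units; beyond the scatter) so the higher level of compound 1 is not unique to its 3-(dimethylamino)phenoxy group. Changing only the aryl group on the oxygen gives no change at the digits printed from compound 1 to compound 4 (within the scatter) so these two aryloxy groups are not separated here, and both aryloxy compounds stand above both alkyl compounds, with none of the four going against this. No supporting measurement bears on the reason for this difference.

The compounds shown leave open whether the higher number goes with the ether oxygen or with the aromatic ring, a question that a benzyl group on this carbon would address. They also leave open whether an unsubstituted phenoxy group would stand level with these two aryloxy groups.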